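From 1H-pyrazol-1-yl to 2-hydroxyphenyl on the shared core

The compounds below may be only part of what the source reports. "The series", "measured", "known", "first", "only" and "open" are said of these compounds alone.

Compound 1 `NC1CCC(Nc2nc(NCc3ccc(-c4ccco4)cc3)c3ncn(C4CCCC4)c3n2)CC1`: 129 nM
Compound 2 `NC1CCC(Nc2nc(NCc3ccc(-c4ccsc4)cc3)c3ncn(C4CCCC4)c3n2)CC1`: 315 nM
Compound 3 `NC1CCC(Nc2nc(NCc3ccc(-n4cccn4)cc3)c3ncn(C4CCCC4)c3n2)CC1`: 320 nM

These three values come from a functional assay on HCT-116 cells (Homo sapiens) for inhibition, with a stated time of 72 h; on this read-out higher numbers stand for weaker inhibition and lower numbers for stronger inhibition. Compound 3 gives 320 nM and sits level with compound 2, the gap being a 1.0-fold higher number from compound 2 to compound 3 (0.01 log units; within the scatter). Compound 1 stands apart, with a 2.5-fold higher number from compound 1 to compound 3 (0.39 log units; beyond the scatter).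

Compound 4 `NC1CCC(Nc2nc(NCc3ccc(-c4ccccc4O)cc3)c3ncn(C4CCCC4)c3n2)CC1` carries one change relative to compound 3: 2-hydroxyphenyl in place of 1H-pyrazol-1-yl on an aromatic carbon. In words, 2-hydroxyphenyl stands in place of 1H-pyrazol-1-yl on an aromatic carbon of a six-membered aromatic ring of carbon only, para to a large group.

Within the data shown here, the measured swaps at this same place are the only guide. They show a 2.4-fold higher number from compound 1 to compound 2 (0.39 log units; beyond the scatter), alongside the two steps already given, so none of them is more than modest. Among the measured compounds shown here, none of the measured compounds has a six-membered ring or a hydroxyl group at this place, so the data do not show what either would do. In this assay, a step of modest size at most is therefore expected, with no firm direction. The estimate amounts to a 1.3-fold lower number from compound 3 to compound 4 (0.11 log units; within the scatter), which is expected to stay within the scatter. For compound 4 the estimated value is 250 nM, with an expected range from 90 nM to 700 nM.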

Compound 4, half-maximal inhibitory concentration: 4350 nM
Beside the measured number, compound 4's estimate is 17-fold (1.24 log units) below it; measured number outside the range, above it.
By their numbers in this assay, from the lowest: compound 1; then compounds 2 and 3 (each within the scatter of the next); then compound 4.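

In this assay, the swaps among furan-2-yl, thiophen-3-yl and 1H-pyrazol-1-yl were modest at most, but 2-hydroxyphenyl gives a 14-fold higher number from compound 3 to compound 4 (1.13 log units; beyond the scatter), along with a 14-fold higher number from compound 2 to compound 4 (1.14 log units; beyond the scatter) and a 34-fold higher number from compound 1 to compound 4 (1.53 log units; beyond the scatter). Among these compounds, compound 4 is thus the weakest of the four, and this place on the ring, para to a large group, proves far less tolerant than the earlier compounds suggested. The change brings in a six-membered aromatic ring of carbon only and a hydroxyl group in a single step, and nothing available explains the loss.

The compounds shown leave open whether the six-membered ring, the hydroxyl group or the two together account for the step, a question that plain phenyl or 2-methoxyphenyl at this place would help to separate. They also leave open whether other groups on the phenyl ring, such as an amine or a carboxylic acid, would give numbers as high as that of compound 4 or stay closer to those of the five-membered rings.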